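Swapping the Sulfonyl Aryl Group and Cell Toxicity

The source may report more compounds than this note shows. Statements on the series, on what has been measured and on what is new or still open speak of the compounds shown alone.

Within the data shown here, compound 2 `COc1ccc(OC)c(S(=O)(=O)Nc2cccc(N3C[C@@H](c4ccc(OC)c(OC5CCCC5)c4)CC3=O)c2)c1` is the only compound here with a plain number in a functional assay on HEK293 cells (Homo sapiens) for cytotoxicity (on this read-out lower numbers stand for higher toxicity in this test and higher numbers for lower toxicity in this test), where compound 2 gives 7590 nM. Compound 1 `COc1ccc([C@H]2CC(=O)N(Cc3cccc(C#N)c3)C2)cc1OC1CCCC1` reaches only a limit in this assay, giving > 10000 nM; this is the limit of > 10000 nM in this assay, at which 1 of the 2 values shown sits. Compound 3 `COc1ccc([C@H]2CC(=O)N(c3cccc(NS(=O)(=O)c4cccc(C)c4)c3)C2)cc1OC1CCCC1` differs from compound 2 by 3-methylphenyl in place of 2,5-dimethoxyphenyl on a sulfonyl sulfur. No measured step of this kind exists among these compounds, so only a small shift is expected, in no clear direction and not beyond the usual scatter. Compound 3 is estimated at 9000 nM, between 4000 nM and 20000 nM, a step of a 1.2-fold higher number from compound 2 to compound 3 (0.07 log units; within the scatter) that is expected to stay within the scatter.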

Compound 3, half-maximal cytotoxic concentration: > 10000 nM
Compound 3: only a limit was reported (the forecaster's own chance of this, stated with the estimate: 40%); middle value at least 1.1-fold (0.04 log units) away from the limit.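

On the sulfonyl sulfur, 3-methylphenyl in place of 2,5-dimethoxyphenyl gives an at least 1.3-fold higher number from compound 2 to compound 3 (0.11 log units; that floor lies within the scatter) in this assay. Among these compounds, this is the first view of this position, and it shows that an aryl group with 0 hydrogen-bond acceptors brings no sign of higher toxicity in this test. Compound 3 gives only a limit, so the full size of the step cannot be read, and such limits now make up most of this small set: the limit of > 10000 nM in this assay, at which 2 of the 3 values shown sit.

Still open, going by these compounds, is whether an amine or a carboxylic acid on this aryl ring would give a clearly lower number. The same goes for a longer alkyl chain in place of the ring.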